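Trading an Isopropyl for an Amino Group

The source may hold more compounds than are shown below. What is called first, only, known or untested is meant among the compounds shown, and "the series" means these compounds.

Compound 2 `CC(C)c1cc(Nc2cc(Cl)cc(Cl)c2)nc(N)n1` belongs to a small set of three compounds that share one core. Compound 1 `Nc1nccc(Nc2cc(Cl)cc(Cl)c2)n1` gives in an assay on cells for inhibition of S-adenosylmethionine decarboxylase proenzyme (Homo sapiens), read by mass spectrometry, at pH 7.2 (a higher number here means a weaker inhibitor, a lower number a stronger inhibitor), a reading of > 180000 nM, which is a limit of the assay and not a number. Compound 2 likewise gives only a limit in this assay, > 180000 nM. Compound 3 `Cc1cc(Nc2cc(Cl)cc(Cl)c2)nc(N(C)C)n1` also gives a limit, > 180000 nM. All three readings sit at the limit of > 180000 nM in this assay, at which 3 of the 3 values shown sit, so none of them shows measurable inhibition on the scale used. Among the measured compounds shown here, both ends of the only one-change step are limits, so the step that the two limits leave unreadable from compound 1 to compound 2 cannot be read in either size or direction.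

Compound 4 `Nc1cc(Nc2cc(Cl)cc(Cl)c2)nc(N)n1` differs from compound 2 by amino in place of isopropyl on an aromatic carbon. For the measured compounds named here, no measured step bears directly on this change, and the single measured step is unreadable. Compound 2 itself sits at the limit, so the expected step that the limit leaves unreadable from compound 2 to compound 4 in this assay cannot be anchored to a number. Compound 4 is therefore estimated to give about 300000 nM, within an expected range from 100000 nM to 1000000 nM, and is expected to return again only a limit.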

Compound 4, half-maximal inhibitory concentration: > 180000 nM
Compound 4 gave a limit, no number (the forecaster's own chance of this, stated with the estimate: 85%); the middle value is on the limit's open side.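

Compound 4 gives > 180000 nM, again a limit of the assay and not a number. Neither the step from compound 1 to compound 4 nor the one from compound 2 to compound 4 can be read, in size or direction: the limit of > 180000 nM in this assay, at which 4 of the 4 values shown sit.

The compounds shown leave open whether any change to the shared core brings measurable inhibition in this assay.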